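The source may report more compounds than this note shows. Statements on the series, on what has been measured and on what is new or still open speak of the compounds shown alone.

Measured in an ADME assay on microsomes from liver (Homo sapiens) for metabolic stability, using NADPH, with a stated time of 10 min; a lower number here means that less of the compound is left, a higher number that more of the compound is left:

- compound 1 `NC(=O)NC/C=C\CN(C[C@H]1Cc2ncccc2CN1)[C@H]1CCCc2cccnc21`: 100%
- compound 2 `NC(=O)NC/C=C/CN(C[C@H]1Cc2ncccc2CN1)[C@H]1CCCc2cccnc21`: 93%
- compound 3 `CN(CCCCN(C[C@H]1Cc2ncccc2CN1)[C@H]1CCCc2cccnc21)C1CCC(F)(F)CC1`: 61%

Compound 3 gives the lowest of these three numbers, and both compound 1 and compound 2 lie above it beyond the scatter. The next compound to be tested is compound 4 `c1cnc2c(c1)CN[C@@H](CN(CCCCNC1COC1)[C@H]1CCCc3cccnc31)C2`, which differs from compound 3 at one place: a group of 5 heavy atoms (3 carbon, 1 nitrogen, 1 oxygen; one four-membered non-aromatic ring with 1 hetero atom) in place of a group of 10 heavy atoms (7 carbon, 1 nitrogen, 2 fluorine; one six-membered non-aromatic ring of carbon only), on a saturated chain carbon, four bonds along the chain from an amine nitrogen. The exchange sits on a saturated chain carbon, four bonds along the chain from an amine nitrogen.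

Going by the values given here, the only measured step between compounds differing in one place is a number 7 percentage points lower from compound 1 to compound 2 (within the scatter). Among the compounds with values here, that step concerns configuration alone (the fact that compounds 1 and 2 differ only in the configuration as drawn), so it says little about an exchange of this kind, and no measured step gives its size directly. Within the data shown here, the only other guide is the values themselves. Compound 3 carries the six-membered non-aromatic ring of carbon only and gives 61%, while compound 2 lacks that ring and gives 93%. However, compound 2 also differs from compound 3 elsewhere, so this guide is a weak one.

A moderate upward step in this assay is therefore expected, estimated as a number 17 percentage points higher from compound 3 to compound 4 (beyond the scatter). For compound 4 the estimated value is 78%, with an expected range from 55% to 98%.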

Compound 4, percent of the compound remaining: 97%
Compound 4: the middle estimate sits 19 percentage points below what was measured, within the range that was stated.
By their numbers in this assay, from the lowest: compound 3; then compounds 2, 4 and 1 (each within the scatter of the next).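

In this assay, the exchange on a saturated chain carbon, four bonds along the chain from an amine nitrogen, of the group with the six-membered non-aromatic ring of carbon only for (oxetan-3-yl)amino gives a number 36 percentage points higher from compound 3 to compound 4 (beyond the scatter), a large step and the only one shown for a change at this place with the saturated chain kept. The number for the oxetane-bearing compound cannot be told apart from those of the two compounds whose group has no ring, as the steps show: a number 4 percentage points higher from compound 2 to compound 4 (within the scatter) and a number 3 percentage points lower from compound 1 to compound 4 (within the scatter). The saturated chain shared by compound 3 and compound 4 therefore does not by itself fix a low number, since the group at its end makes a difference beyond the scatter.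

The exchange alters the ring, the size of the group and the substitution on its nitrogen all at once, so the compounds shown leave open which of these carries the step, and a methyl on the nitrogen of the (oxetan-3-yl)amino group or a tetrahydropyran ring in place of the oxetane would bear on that question. Nothing at hand speaks to the reason for the size of this step.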